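The source may report more compounds than this note shows. Statements on the series, on what has been measured and on what is new or still open speak of the compounds shown alone.

Working notes on a small set of oxazoline ethers in a functional assay on the whole organism for inhibition, with Rattus norvegicus as the target, read by paw edema, with a stated time of 30 min, at a dose of 20 mg/kg by the oral route; on this read-out lower numbers stand for a weaker effect and higher numbers for a stronger effect at the one dose given.

Compound 1 `Clc1ccc(OCC2=NCCO2)cc1` gives 30.3% in this assay. Compound 2 `Cc1ccccc1OCC1=NCCO1` gives 3.1% in this assay, the lowest of the three numbers, and the gap to both of the others lies beyond the usual scatter. The difference between the cores of compound 1 and compound 2 is not broken down here. Compound 3 `Cc1cc(OCC2=NCCO2)ccc1Cl` gives 22.2% in this assay. Compound 3 differs from compound 1 by methyl in place of hydrogen on an aromatic carbon, and this change produced a number 8.1 percentage points lower from compound 1 to compound 3 (within the scatter), a step that stays within the scatter.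

Compound 4 `Cc1ccc(OCC2=NCCO2)c(C)c1` has not yet been measured in this assay. It differs from compound 2 by methyl in place of hydrogen on an aromatic carbon. Going by the values given here, this is the same kind of change as the one from compound 1 to compound 3, but not the same change: in compound 3 the entering methyl sits ortho to a chloro group and meta to a group of 7 heavy atoms, whereas in compound 4 it sits meta to a methyl group and para to a group of 7 heavy atoms.

Among the compounds with values here, for compound 4 the step is expected to be a number 6.9 percentage points higher from compound 2 to compound 4 (within the scatter), a little larger than the one from compound 1 to compound 3 but still modest, because a number 8.1 percentage points lower from compound 1 to compound 3 (within the scatter) shows that the same kind of change barely moved the read-out, while the only support for a rise is that compound 1, carrying its substituent para to the larger group, gives 30.3%. Compound 4 is therefore estimated at 10% in this assay, expected to fall between 0% and 25%.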

Compound 4, a percentage reported as inhibition, in the whole organism at one dose (the size of the read-out at that dose, not a potency): 31.4%
Compound 4: the middle estimate sits 21.4 percentage points below what was measured; the measured number lies above the stated range.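

In this assay, adding the methyl to the ring of compound 2 gives a number 28.3 percentage points higher from compound 2 to compound 4 (beyond the scatter). This change therefore does not carry over from one core to another in this series as a fixed increment: the same change on two cores in this assay, a number 8.1 percentage points lower (within the scatter) from compound 1 to compound 3 and a number 28.3 percentage points higher (beyond the scatter) from compound 2 to compound 4, 36.4 percentage points apart, beyond the scatter of two such steps

What this does not show is why the two steps part, since the comparison rests on one pair per core, the cores differ, and the methyl enters at a different place in each pair, in compound 4 meta to a methyl group and para to a group of 7 heavy atoms. Core and place cannot be separated with these compounds, and no rule for the size or direction of the step can be drawn from two pairs.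

The compounds shown carry only methyl and chloro groups on the aromatic ring, which leaves open how a methoxy group, an amine or a carboxylic acid at these places would behave on either core. They also leave open whether a longer chain between the aromatic ring and the oxygen-bearing ring would keep these differences, and each number here is a read-out at a single dose, not a potency.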